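Methoxy in Place of Fluoro: Expected Anticonvulsant Dose

A few compounds are considered here, and "the series" means these few. Any claim that something is new, unique, unknown or untested is made for them only; others in the source may bear on it.

Compound 1, `CNC(=S)Nc1ccc(S(=O)(=O)Nc2nc3ccc(F)cc3s2)cc1`, gives 300 mg/kg in a functional assay on the whole organism with Mus musculus as the target, in the maximal electroshock model, with a stated time of 0.5 h; on this read-out lower numbers stand for an effect already at smaller amounts and higher numbers for an effect only at larger amounts of compound.
Compound 2, `CCNC(=S)Nc1ccc(S(=O)(=O)Nc2nc3ccc(F)cc3s2)cc1`, gives 300 mg/kg in this assay.

For the measured compounds named here, only two compounds have been measured so far, and they stand level: the step of no change at the digits printed from compound 1 to compound 2 (within the scatter) shows that adding a methyl on the saturated chain carbon bound to an amide-type nitrogen left the minimum effective dose where it was. Compound 1 therefore has no neighbour that is clearly stronger or weaker; it simply shares its value with compound 2.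

Compound 3, `CNC(=S)Nc1ccc(S(=O)(=O)Nc2nc3ccc(OC)cc3s2)cc1`, is the next compound to be tested. It differs from compound 1 in one place: methoxy in place of fluoro on an aromatic carbon. Going by the values given here, no measured step touches this part of the shared core, so the only guidance is the one step that exists, which was flat and concerned a different position. With nothing pointing up or down, the expectation for compound 3 is a dose in line with compound 1, that is, no step beyond the scatter, which is what the expected no change at the digits printed from compound 1 to compound 3 (within the scatter) means. Compound 3 is estimated at 300 mg/kg, with a likely range from 150 mg/kg to 600 mg/kg.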

Compound 3, minimum effective dose: 300 mg/kg
For compound 3 middle estimate and measured number coincide at the digits printed; low and high end bracket the measured number.
By their numbers in this assay, from the lowest: compounds 1, 2 and 3 (each within the scatter of the next).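

Exchanging fluoro for methoxy on this aromatic carbon, where fluoro counts 1 heavy atom and no hydrogen-bond acceptor and methoxy counts 2 heavy atoms and 1 hydrogen-bond acceptor, gives no change at the digits printed from compound 1 to compound 3 (within the scatter) in this assay. For the compounds shown here, the earlier step spoke only about the saturated chain carbon bound to an amide-type nitrogen, so this is the first reading from the aromatic part of the shared core, and for this one exchange the minimum effective dose stays level there as well. No supporting information is available to explain this result.

The compounds shown leave open whether a different group on the same aromatic carbon, such as an amine, a carboxylic acid or a longer chain like ethoxy, would move the dose in either direction. With all three compounds level, they also leave open whether any change to the shared core can bring the effect down to a clearly smaller dose, and a single exchange cannot show how far this position tolerates change in general.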